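Moving a methoxy group on the phenoxy side chain

The source may hold more compounds than are shown below. What is called first, only, known or untested is meant among the compounds shown, and "the series" means these compounds.

Compound 2: `COc1cccc(OCC(O)CN2CCC(N3Cc4ccccc4C3=O)CC2)c1` – 910 nM
Compound 1: `O=C1CCc2c(cccc2N2CCN(CC(O)COc3ccccc3C(=O)c3ccccc3)CC2)N1` – 2400 nM

Of the compounds shown here, two have been measured in an assay on isolated protein for inhibition of sodium channel protein type 9 subunit alpha (Mus musculus), read by patch clamp; on this read-out lower numbers stand for stronger inhibition and higher numbers for weaker inhibition. Compound 2 gives 910 nM and carries the lowest of the two numbers. Its nearest neighbour is compound 1 with 2400 nM, a number that lies beyond the scatter of repeated measurements, so compound 2 stands as the stronger inhibitor of the pair. For the measured compounds named here, the two compounds share no single-point step, so nothing can be said about what one group does on its own.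

The untested compound 3 is `COc1ccc(OCC(O)CN2CCC(N3Cc4ccccc4C3=O)CC2)cc1`. It keeps every atom of compound 2 and rearranges only one part:

4-methoxyphenyl in place of 3-methoxyphenyl on an oxygen on a saturated carbon

Going by the values given here, no measured pair shows a change of this kind, so there is no direct guide to its effect. In this assay the step is therefore expected to be small, in either direction or none beyond the scatter, and the estimated step is a 1.3-fold higher number from compound 2 to compound 3 (0.12 log units; within the scatter). On that basis compound 3 is expected to give about 1200 nM in this assay, within a range of 400 nM to 3600 nM.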

Compound 3, half-maximal inhibitory concentration: 1300 nM
Estimate against measurement, compound 3: 1.1-fold (0.03 log units) below; the range from low to high includes it.
By their numbers in this assay, from the lowest: compounds 2, 3 and 1 (each within the scatter of the next, the first and the last beyond it).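

In this assay, the change from 3-methoxyphenyl to 4-methoxyphenyl on an oxygen on a saturated carbon is a 1.4-fold higher number from compound 2 to compound 3 (0.15 log units; within the scatter) and gives the series its first step at a single place. At this position, the read-out does not separate the two placements of the methoxy group, so the 3-methoxyphenoxy and 4-methoxyphenoxy compounds stand level within the scatter. No measurement bears on why the change leaves the number within the scatter.

The compounds shown leave open whether the methoxy group matters at all, since compound 2 and compound 3 both carry it and neither is paired with a plain phenyl, a chlorophenyl or a phenyl bearing a carboxylic acid. For the compounds shown here, they also leave open how far compound 1 can be related to the other two, since it differs from them in several places at once and no single step connects it to either.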